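The source may hold more compounds than are shown below. What is called first, only, known or untested is meant among the compounds shown, and "the series" means these compounds.

Compound 1 `COc1cc(Cc2cc(C)nn(CC(=O)Nc3ccc(Br)cc3)c2=O)cc(OC)c1` gives only a limit in an assay on HL-60 cells for agonist activity at N-formyl peptide receptor 3 (Homo sapiens), read by calcium flux (a lower number here means that less compound is needed, a higher number that more compound is needed for the effect), > 50000 nM.
Compound 2 `Cc1cc(Cc2ccsc2)c(=O)n(CC(=O)Nc2ccc(Br)cc2)n1` also gives only a limit in this assay, > 50000 nM.

Compound 2 thus stands at the limit of this assay, with no number attached. Among the compounds with values here, the one measured step, a step that the two limits leave unreadable from compound 1 to compound 2, cannot be sized, as both of its ends are limits (the limit of > 50000 nM in this assay, at which 2 of the 2 values shown sit). Compound 3 `Cc1cc(Cc2cccnc2)c(=O)n(CC(=O)Nc2ccc(Br)cc2)n1` differs from compound 2 by pyridin-3-yl in place of thiophen-3-yl on a saturated chain carbon bound to an aromatic carbon. Within the data shown here, no measured step bears on this change, so no shift beyond the scatter is expected in this assay. Compound 3 is therefore estimated at 80000 nM (range 20000 nM to 300000 nM), an expected step that the limit leaves unreadable from compound 2 to compound 3 that is essentially none, most likely again only a limit.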

Compound 3, half-maximal effective concentration: > 50000 nM
Compound 3: a limit, no number; the forecaster's own chance of this, stated with the estimate: 85%; the middle value does not contradict the limit.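

In this assay compound 3 gives > 50000 nM, again a limit, so no step among compound 1, compound 2 and compound 3 can be read: the limit of > 50000 nM in this assay, at which 3 of the 3 values shown sit.

The compounds shown leave open whether any group at this place gives a readable value in this assay.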